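The compounds below may be only part of what the source reports. "The series", "measured", "known", "first", "only" and "open" are said of these compounds alone.

Compound 1 `c1ccc(CC2CCN(CCCc3c[nH]c4ccc(-n5cnnc5)cc34)CC2)cc1` is the reference point here. For the measured compounds named here, in a functional assay on CHO cells for agonist activity at 5-hydroxytryptamine receptor 1B (Homo sapiens), read by GTPgammaS binding (a lower number here means that less compound is needed, a higher number that more compound is needed for the effect), compound 1 gives 120 nM, the lowest of the two numbers measured so far. Going by the values given here, its only measured neighbour is compound 2 `CN(Cc1ccccc1)C1CCN(CCCc2c[nH]c3ccc(-n4cnnc4)cc23)CC1`, which in this assay gives 1400 nM; the step of a 12-fold higher number from compound 1 to compound 2 (1.07 log units; beyond the scatter) accompanied benzyl(methyl)amino in place of benzyl on a saturated ring carbon.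

Compound 3 `FC1(Cc2ccccc2)CCN(CCCc2c[nH]c3ccc(-n4cnnc4)cc23)CC1` is the next compound in line. It differs from compound 1 by fluoro in place of hydrogen on a saturated ring carbon. Among the compounds with values here, the one measured step is of a different kind: there the benzyl group itself was exchanged for a nitrogen-linked group, and the number rose by a large amount. In compound 3 the benzyl group is kept, and a fluoro is added to the same saturated ring carbon that bears it. Within the data shown here, no measured pair shows what a fluoro at that position does, so the only guidance is that the benzyl-bearing carbon is left otherwise intact. The step of a 1.3-fold higher number from compound 1 to compound 3 (0.10 log units; within the scatter) is therefore expected to be small, within or near the scatter, in either direction. Compound 3 is estimated to give 150 nM in this assay, with a range from 50 nM to 500 nM.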

Compound 3, half-maximal effective concentration: 66 nM
The estimate for compound 3 lay 2.3-fold (0.36 log units) above the measured number; the measured number falls inside the stated range.
By their numbers in this assay, from the lowest: compounds 3 and 1 (each within the scatter of the next); then compound 2.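

In this assay, the change shows a 1.8-fold lower number from compound 1 to compound 3 (0.26 log units; within the scatter), so fluoro in place of hydrogen on this saturated ring carbon leaves the number within the scatter of compound 1. For the compounds shown here, until now, the only information about this ring carbon was a 12-fold higher number from compound 1 to compound 2 (1.07 log units; beyond the scatter), a step beyond the scatter that replaced the benzyl group itself; the new pair shows that, with benzyl kept, this carbon can carry a fluoro without a change beyond the scatter, so the two steps from compound 1 differ clearly in size at the same ring carbon. Nothing given here explains why the fluoro step stays so small or why the earlier step is large.

Going by these compounds alone, with fluoro as the only new group on this carbon, it remains open whether a hydroxyl group, a methyl group or an amine there would also stay within the scatter of compound 1. Going by these compounds, it also remains open whether the fluoro step would stay as small with the benzyl(methyl)amino group of compound 2 in place of benzyl.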